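Amide-nitrogen substituent and tolerated concentration in this series

This account rests on a few compounds, and the source may have more. Where it says the series, first, only, none or still open, it means among the compounds named here.

In an ADME assay on HepG2 cells (Homo sapiens) for cytotoxicity, with a stated time of 3 days (a higher number here means that more compound is tolerated, a lower number that less compound is tolerated), compound 2 `CC(CSc1nnc(-c2ccncc2)s1)C(=O)Nc1c(Cl)cccc1Cl` gives > 50000 nM, which is a limit of the assay rather than a number. Compound 1 `CC(CSc1nnc(-c2ccncc2)s1)C(=O)Nc1ccc(Cl)cc1` gives > 50000 nM in the same assay, also a limit. Both values thus sit at the limit of > 50000 nM in this assay, at which 2 of the 2 values shown sit, and the step that the two limits leave unreadable from compound 1 to compound 2 between them cannot be read in size or direction. Compound 3 `CC(CSc1nnc(-c2ccncc2)s1)C(=O)NCc1ccccc1` is not yet measured in this assay. It differs from compound 2 in one place: benzyl in place of 2,6-dichlorophenyl on an amide-type nitrogen. Among the compounds with values here, no measured step bears on benzyl in place of 2,6-dichlorophenyl on this nitrogen, and the single step that is known is itself unreadable, so nothing points to a change beyond the scatter. Compound 3 is therefore expected to sit at the same limit, with an estimate of 55000 nM, ranging from 20000 nM to 150000 nM. This expected estimate means a step that the limit leaves unreadable from compound 2 to compound 3.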

Compound 3, half-maximal cytotoxic concentration: > 50000 nM
Compound 3 gave a limit, no number; the forecaster's own chance of this, stated with the estimate: 80%; the middle value does not contradict the limit.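

Within the data shown here, no step between compound 1, compound 2 and compound 3 can be read in this assay, as all three values are limits and not numbers: the limit of > 50000 nM in this assay, at which 3 of the 3 values shown sit.

The compounds shown leave open whether any substituent on this amide nitrogen brings the tolerated concentration into a readable range, and how 4-chlorophenyl, 2,6-dichlorophenyl and benzyl compare there.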